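A few compounds are considered here, and "the series" means these few. Any claim that something is new, unique, unknown or untested is made for them only; others in the source may bear on it.

Measured so far in a functional assay on MDA-MB-231 cells (Homo sapiens) for cytotoxicity, read by MTT assay, with a stated time of 72 h; on this read-out lower numbers stand for stronger inhibition and higher numbers for weaker inhibition:
- compound 1 `Cc1ccc(Cn2cc(/C=N/NC(=O)Nc3nc4ccc(CN(C)C)cc4s3)c3ccccc32)cc1`: 1220 nM
- compound 2 `Cc1ccc(Cn2cc(/C=N/NC(=O)Nc3nc4ccc(CN5CCC(C)CC5)cc4s3)c3ccccc32)cc1`: 1140 nM

Compound 1 stands highest of the two numbers; its nearest neighbour is compound 2, and a 1.1-fold lower number from compound 1 to compound 2 (0.03 log units; within the scatter) is within the scatter. That step concerns the amine on the saturated chain carbon and says nothing about the benzyl ring.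

Compound 3 `CN(C)Cc1ccc2nc(NC(=O)N/N=C/c3cn(Cc4ccc(Cl)cc4)c4ccccc34)sc2c1` differs from compound 1 by chloro in place of methyl on an aromatic carbon. Among the measured compounds shown here, no measured step touches this place, so no direction beyond the scatter is expected in this assay. Compound 3 is expected to give 1200 nM, with a range from 500 nM to 2900 nM. For compound 3 the estimated step is a 1.0-fold lower number from compound 1 to compound 3 (0.01 log units; within the scatter).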

Compound 3, half-maximal inhibitory concentration: 880 nM
The estimate for compound 3 lay 1.4-fold (0.13 log units) above the measured number; the range from low to high includes it.
By their numbers in this assay, from the lowest: compounds 3, 2 and 1 (each within the scatter of the next).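

Among the compounds shown here, the first measured change at this place on the benzyl ring, 4-methylbenzyl to 4-chlorobenzyl, reads in this assay as a 1.4-fold lower number from compound 1 to compound 3 (0.14 log units; within the scatter) and so sets no direction. With the dimethylamino side chain held constant, chloro in place of methyl on this aromatic carbon, para to a large group, leaves the number within the scatter. Nothing at hand accounts for the result.

Still open, going by these compounds, is whether methoxy, trifluoromethyl or plain hydrogen at this place would move the number beyond the scatter. Also open, on these data alone, is whether chloro reads the same alongside the 4-methylpiperidin-1-yl amine.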